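One exchange on a carbonyl carbon of compound 2

A few compounds are considered here, and "the series" means these few. Any claim that something is new, unique, unknown or untested is made for them only; others in the source may bear on it.

Measured so far in a physicochemical assay for lipophilicity, measured as octanol-water partition, at pH 7.4; on this read-out lower numbers stand for lower lipophilicity and higher numbers for higher lipophilicity
compound 1 `Cc1ccc2[nH]c(C(=O)N[C@H]3CN(S(=O)(=O)c4ccccc4)C[C@@H]3C(=O)NC[C@H]3CCCN3C)cc2c1` gives 2.3
compound 2 `O=C(N[C@H]1CN(S(=O)(=O)c2ccccc2)C[C@@H]1C(=O)N1C[C@H]2CCNC[C@H]21)c1cc(-c2ccccc2Cl)on1` gives 1.7

Of these two numbers, compound 2 holds the lower, and compound 1 lies above it by a gap beyond the usual scatter. Compound 3 `CN1CCC[C@H](NC(=O)[C@H]2CN(S(=O)(=O)c3ccccc3)C[C@@H]2NC(=O)c2cc(-c3ccccc3Cl)on2)C1` has not yet been measured. It differs from compound 2 in one place, on a carbonyl carbon whose other neighbour is a saturated ring carbon. There (1-methylpiperidin-3-yl)amino takes the place of a group with one four-membered and one six-membered non-aromatic ring a group of 8 heavy atoms (6 carbon, 2 nitrogen; one six-membered non-aromatic ring with 1 hetero atom) in place of a group of 8 heavy atoms (6 carbon, 2 nitrogen; one four-membered non-aromatic ring with 1 hetero atom, one six-membered non-aromatic ring with 1 hetero atom), on a carbonyl carbon and nothing else changes. Among the compounds with values here, no measured step covers this exchange, so the expectation rests only on compound 2 at 1.7 and compound 1 at 2.3 as the two available anchors. An upward move is expected, with a number 0.50 log units higher from compound 2 to compound 3 (beyond the scatter) as the estimated size, and such a move would lie beyond the scatter in this assay if it holds. For compound 3 the expected value is 2.2 with 1.7 to 2.7 as the estimated range.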

Compound 3, distribution coefficient: 3.1
The estimate for compound 3 lay 0.90 log units below the measured number; the whole stated range lies below it.
By their numbers in this assay, from the lowest: compound 2; then compound 1; then compound 3.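

At this position, on a carbonyl carbon whose other neighbour is a saturated ring carbon, this assay proves highly responsive to the amine-bearing group: exchanging the group with one four-membered and one six-membered non-aromatic ring for (1-methylpiperidin-3-yl)amino gives a large move, a number 1.40 log units higher from compound 2 to compound 3 (beyond the scatter) and nothing else in the structure changes. The two groups match in heavy atoms, in carbon and nitrogen, in hydrogen-bond donors and acceptors and in having no net charge, and these counts therefore do not separate them; the printed differences lie in the ring make-up and the number of defined stereocentres. Nothing available gives a measured reason for the size of this step. The compounds shown leave open which part of the exchange carries the step, since piperidin-3-ylamino without the methyl on its ring nitrogen, or a morpholine on the same carbonyl carbon, would help to divide it. They also leave open whether (1-methylpiperidin-3-yl)amino would give a similar step with a group other than the chlorophenyl-bearing amide elsewhere on the shared core.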